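Opening the pyrrolidine ring of compound 2 into an acyclic amino acid

The compounds below may be only part of what the source reports. "The series", "measured", "known", "first", "only" and "open" are said of these compounds alone.

Measured compounds, in a functional assay on HeLa cells (Homo sapiens) for antiproliferative activity, read by CCK-8 assay, with a stated time of 48 h; a higher number here means a weaker inhibitor, a lower number a stronger inhibitor:
Compound 1 `COc1ccc(/C=C\c2cc(OC)c(OC)c(OC)c2)cc1OCc1ccc(CN2CC[C@H](O)C2)cc1` gives 10500 nM.
Compound 2 `COc1ccc(/C=C\c2cc(OC)c(OC)c(OC)c2)cc1OCc1ccc(CN2CC[C@@H](C(=O)O)C2)cc1` gives 12800 nM.

Compound 2 has the highest of the two numbers, and its nearest neighbour is compound 1, with a gap that lies within the scatter. Compound 3 `COc1ccc(/C=C\c2cc(OC)c(OC)c(OC)c2)cc1OCc1ccc(CN[C@H](C(=O)O)[C@@H](C)O)cc1` carries the change ((1-carboxy-2-hydroxypropyl)amino in place of 3-carboxypyrrolidin-1-yl on a saturated chain carbon bound to an aromatic carbon). Among the compounds with values here, the only measured step bears on the same place: a 1.2-fold higher number from compound 1 to compound 2 (0.09 log units; within the scatter), a change of the group on that saturated chain carbon that left this assay essentially unmoved. Within the data shown here, compound 3 keeps the carboxy group of compound 2 and adds a hydroxy group in an acyclic arrangement; with no measured precedent for ring opening here, the expectation is that compound 3 stays close to compound 2, with an expected step of a 1.0-fold higher number from compound 2 to compound 3 (0.01 log units; within the scatter). Compound 3 is therefore estimated at 13000 nM, in a range from 5000 nM to 35000 nM.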

Compound 3, half-maximal inhibitory concentration: > 10000 nM
Compound 3 gave a limit, no number (the forecaster's own chance of this, stated with the estimate: 10%); the middle value is on the limit's open side.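

In this assay compound 3 gives > 10000 nM, which is a limit and not a number. Its steps from compound 1 and from compound 2 cannot be read. The compounds shown leave open how (1-carboxy-2-hydroxypropyl)amino in place of 3-carboxypyrrolidin-1-yl actually moves this assay.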